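A few compounds are considered here, and "the series" means these few. Any claim that something is new, unique, unknown or untested is made for them only; others in the source may bear on it.

All the compounds here share one core and differ only in the group on a double-bonded chain carbon bound to a double-bonded chain carbon. In a functional assay on A549 cells (Homo sapiens) for cytotoxicity, read by MTT assay, with a stated time of 72 h (on this read-out lower numbers stand for stronger inhibition and higher numbers for weaker inhibition), compound 3 `COc1cc(/C=C/C(=O)Nc2cc3c(Nc4ccc(F)c(Cl)c4)ncnc3cc2O[C@H]2CCOC2)cc(OC)c1` gives 10800 nM. Compound 1 `O=C(/C=C/c1ccc([N+](=O)[O-])cc1)Nc1cc2c(Nc3ccc(F)c(Cl)c3)ncnc2cc1O[C@H]1CCOC1` gives 12000 nM. Going by the values given here, these two numbers lie within the scatter of each other, so compound 3 stands level with the only other compound that has a number. Compound 2 `N#Cc1ccc(/C=C/C(=O)Nc2cc3c(Nc4ccc(F)c(Cl)c4)ncnc3cc2O[C@H]2CCOC2)cc1` is reported as "not active" (no number reported), which leaves nothing to rank it by.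

Still to be measured is compound 4 `O=C(/C=C/c1ccc(Br)cc1)Nc1cc2c(Nc3ccc(F)c(Cl)c3)ncnc2cc1O[C@H]1CCOC1`, and its change from compound 3 is this: 4-bromophenyl in place of 3,5-dimethoxyphenyl on a double-bonded chain carbon bound to a double-bonded chain carbon. In words, 4-bromophenyl takes the place of 3,5-dimethoxyphenyl. Among the compounds with values here, one measured step bears on this swap at the same place: a 1.1-fold lower number from compound 1 to compound 3 (0.05 log units; within the scatter). That step stays within the scatter. Compound 2 goes against any rule that this place accepts every group, as it ended as "not active" (no number reported). Within the data shown here, no measured compound carries bromine, and a result without a number remains possible for compound 4.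

A step beyond the scatter is not expected in either direction. The expected change is a 1.0-fold higher number from compound 3 to compound 4 (0.01 log units; within the scatter). For compound 4 the estimated value is 11000 nM, with an expected range of 5500 nM to 22000 nM.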

Compound 4, half-maximal inhibitory concentration: 35300 nM
Compound 4: the middle estimate sits 3.2-fold (0.51 log units) below what was measured, outside the stated range (above it).
By their numbers in this assay, from the lowest: compounds 3 and 1 (each within the scatter of the next); then compound 4.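

In this assay, the earlier numbers made the group on a double-bonded chain carbon bound to a double-bonded chain carbon look interchangeable, but 4-bromophenyl in place of 3,5-dimethoxyphenyl breaks that picture and gives a 3.3-fold higher number from compound 3 to compound 4 (0.51 log units; beyond the scatter) as a modest change. The comparison with compound 1 points the same way, with bromo in place of nitro on an aromatic carbon giving a 2.9-fold higher number from compound 1 to compound 4 (0.47 log units; beyond the scatter) as another modest change, so this place can shift the number even when the ring stays a phenyl and only what it carries differs. Compound 4 therefore has the highest number of the three compounds with a value. Compound 2 has no number and stays outside this order, and the 3,5-dimethoxyphenyl and 4-nitrophenyl groups remain level with each other.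

The compounds shown leave open how a phenyl ring carrying an amine, a carboxylic acid or a fluoro group would behave here, and whether a longer chain would keep the number near that of compound 3 or move it further up. Nothing shown gives a measured reason for the shift seen with compound 4.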